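Replacing pyrimidin-2-yl on the ring amine nitrogen

The source may report more compounds than this note shows. Statements on the series, on what has been measured and on what is new or still open speak of the compounds shown alone.

In a physicochemical assay for lipophilicity, read by HPLC, measured as chromatographic lipophilicity, at pH 7.4 (on this read-out lower numbers stand for lower lipophilicity and higher numbers for higher lipophilicity), compound 1 `O=C(C1CCN(c2ccccc2)CC1)N1N=CC[C@H]1c1ccccc1` gives 6.3 and compound 2 `O=C(C1CCN(c2ncccn2)CC1)N1N=CC[C@H]1c1ccccc1` gives 4.7 as the lower of the two numbers. Compound 3 `O=C(c1cnco1)N1CCC(C(=O)N2N=CC[C@H]2c2ccccc2)CC1` differs at one place ((1,3-oxazol-5-yl)carbonyl in place of pyrimidin-2-yl on an amine nitrogen in a ring) and carries (1,3-oxazol-5-yl)carbonyl in place of pyrimidin-2-yl on an amine nitrogen in a ring. Among the measured compounds shown here, the one measured step at that place is large and beyond the scatter (a number 1.60 log units lower from compound 1 to compound 2 (beyond the scatter)) but swaps a different pair of groups, so it guides the size only loosely. A moderate further fall in this assay is expected (a number 0.80 log units lower from compound 2 to compound 3 (beyond the scatter)) on this basis. Compound 3 is estimated at 3.9 with a range from 3.1 to 4.6 on this read-out.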

Compound 3, distribution coefficient: 2.7
Beside the measured number, compound 3's estimate is 1.20 log units above it, and the stated range ends above it.
By their numbers in this assay, from the lowest: compound 3; then compound 2; then compound 1.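

With (1,3-oxazol-5-yl)carbonyl on the amine nitrogen in the ring, this assay shows a number 2.00 log units lower from compound 2 to compound 3 (beyond the scatter). The position therefore still moves this read-out beyond the scatter after pyrimidin-2-yl, and the full span reaches a number 3.60 log units lower from compound 1 to compound 3 (beyond the scatter). Nothing available gives a reason for either step.

Going by these compounds, the change brings in the carbonyl and the five-membered aromatic ring together, so the share of each in the step stays open. Benzoyl or acetyl on the same nitrogen would help to separate them.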